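This account rests on a few compounds, and the source may have more. Where it says the series, first, only, none or still open, it means among the compounds named here.

Measured so far, in an ADME assay on HEK-293T cells (Homo sapiens) for cytotoxicity, read by luminescence and CellTiter-Glo, with a stated time of 24 h; a lower number here means that less compound is tolerated, a higher number that more compound is tolerated:

Compound 1 `CCCNC(=O)[C@@H]1C[C@H]2CCC[C@@H](C1)[C@@H]2NC(=O)c1cc2scnc2n1Cc1ccc(OC)cc1`. In this assay compound 1 gives > 25000 nM, which is a limit of the assay and not a number.

Compound 2 `CCCNC(=O)[C@@H]1C[C@H]2CCC[C@@H](C1)[C@@H]2NC(=O)c1cc2sc(-c3ccccc3)nc2n1Cc1ccc(OC)cc1`. In this assay compound 2 gives > 100000 nM, again a limit of the assay.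

Compound 3 `CCCNC(=O)C1CCN(C(=O)c2cc3sc(-c4ccccc4)cc3n2Cc2ccc(OC)cc2)CC1`. In this assay compound 3 gives > 100000 nM, also a limit of the assay.

Compound 2 and compound 1 differ in one place: hydrogen in place of phenyl on an aromatic carbon. The step that the two limits leave unreadable from compound 2 to compound 1 cannot be read, since one value sits at the limit of > 100000 nM in this assay, at which 2 of the 3 values shown sit, and the other at the limit of > 25000 nM in this assay, at which 1 of the 3 values shown sits; neither end is a number, so no direction or size of change follows from the pair.

Compound 3 shares the same kind of change with compound 4, which is not yet measured: `CCCNC(=O)C1CCN(C(=O)c2cc3sccc3n2Cc2ccc(OC)cc2)CC1`. Here (hydrogen in place of phenyl on an aromatic carbon). The difference between the cores of compound 2 and compound 3 is not broken down here. The two places are not the same word for word: in compound 2 the five-membered aromatic ring holds 1 nitrogen and 1 sulfur, with the site next to the ring nitrogen and next to the ring sulfur, whereas in compound 3 the ring holds 1 sulfur only, with the site next to the ring sulfur. It is therefore the same kind of change, not the same change.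

The expectation for compound 4 rests on compound 3 giving > 100000 nM, a limit, and on compound 1 and compound 2 both sitting at limits after the related change. The step from compound 3 to compound 4 is expected to be about a number no higher from compound 3 to compound 4 (the limit leaves the size open), most likely again returned as a limit. Compound 4 is estimated at 100000 nM, with a range of 30000 nM to 300000 nM.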

Compound 4, half-maximal cytotoxic concentration: 18800 nM
Beside the measured number, compound 4's estimate is 5.3-fold (0.73 log units) above it, and the stated range ends above it.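

In this assay, hydrogen in place of phenyl on an aromatic carbon gives an at least 5.3-fold lower number from compound 3 to compound 4 (0.72 log units; beyond the scatter), so on the core of compound 3 less compound is tolerated once the phenyl is gone, and the true size of the step may be larger, as only a limit stands at its starting end. The same kind of change on the core of compound 2 cannot be read, since compound 2 and compound 1 both stand at limits of the assay, so nothing here shows whether the drop carries over from one core to the other. The two places also differ, the five-membered aromatic ring holding 1 sulfur in compound 3 and 1 nitrogen and 1 sulfur in compound 2, so a single readable step sets no rule for the series and gives no cause for the drop.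

Open, on these data alone, is how a methyl, an amine or a carboxylic acid on this aromatic carbon of the core of compound 4 would compare with hydrogen and phenyl. Also open, as far as these compounds go, is the number behind each limit, and with it whether this change lowers the number on the core of compound 2 at all.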